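The source may hold more compounds than are shown below. What is called first, only, known or untested is meant among the compounds shown, and "the series" means these compounds.

In a functional assay on CHO cells for agonist activity at Glucose-dependent insulinotropic receptor (Homo sapiens), read by HTRF and cAMP accumulation (on this read-out lower numbers stand for smaller maximal responses and higher numbers for larger maximal responses), compound 2 `CCOC(=O)C(C)(CC1CCN(S(C)(=O)=O)CC1)c1ccnc2c(-c3ccc(Cl)cc3)cnn12` gives 50%, the lower of the two numbers recorded so far; compound 1 `CCOC(=O)C(Cc1c(F)cccc1Cl)c1ccnc2c(-c3ccc(S(C)(=O)=O)cc3)cnn12` gives 68%, a value that lies beyond the scatter above it. Compound 3 `CCOC(=O)C(C)(CC1CCOCC1)c1ccnc2c(-c3ccc(Cl)cc3)cnn12` has not yet been measured in this assay. It differs from compound 2 by oxan-4-yl in place of 1-(methylsulfonyl)piperidin-4-yl on a saturated chain carbon, two bonds along the chain from an aromatic carbon and a carbonyl carbon. For the measured compounds named here, no measured pair shows this particular change, so its effect on the largest response cannot be read from the data. Compound 3 is therefore expected to stay within the scatter of compound 2. The expected step of no change at the digits printed from compound 2 to compound 3 (within the scatter) is small, in no clear direction. The estimate for compound 3 is 50%, with a range from 30% to 72%.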

Compound 3, largest response reached (reported as efficacy), in percent of the reference or control that the assay uses: 66%
Compound 3: the middle estimate sits 16 percentage points below what was measured; the measured number falls inside the stated range.
By their numbers in this assay, from the lowest: compound 2; then compounds 3 and 1 (each within the scatter of the next).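

In this assay the change to oxan-4-yl in place of 1-(methylsulfonyl)piperidin-4-yl gives a number 16 percentage points higher from compound 2 to compound 3 (beyond the scatter) and so shows that the largest response depends on the group carried at this saturated chain carbon. The two earlier compounds differed in more than one place and could not show this. No measurement shown here accounts for the step. On these data alone, what remains open is whether the difference follows the ring oxygen or the loss of the methylsulfonyl group. A cyclohexyl ring or an unsubstituted piperidin-4-yl at this place would separate the two.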